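A few compounds are considered here, and "the series" means these few. Any claim that something is new, unique, unknown or untested is made for them only; others in the source may bear on it.

In a functional assay on HCT-116 cells (Homo sapiens) for inhibition, read by CCK-8 assay, with a stated time of 72 h, tested at 8 uM (on this read-out higher numbers stand for more inhibition of growth at the one concentration tested and lower numbers for less inhibition of growth), compound 2 `COc1ccc(SCc2ccc(C(=O)Nc3ccccc3N)cc2)cc1` gives 90.1% and stands highest of the three measured compounds. Compound 1 `COc1ccc(SCc2ccc(/C=C/C(=O)Nc3ccccc3N)cc2)cc1OC` gives 49.5% and compound 3 `Nc1ccccc1NC(=O)/C=C/c1ccc(CSc2cccc3ccccc23)cc1` gives 35.2% in the same test, both lower than compound 2 beyond the scatter. Compound 4 `CC(C)(C)c1ccc(SCc2ccc(C(=O)Nc3ccccc3N)cc2)cc1` differs from compound 2 by tert-butyl in place of methoxy on an aromatic carbon with tert-butyl in place of methoxy on an aromatic carbon, para to a large group. Among the measured compounds shown here, no measured step covers tert-butyl itself. The nearest evidence is a number 14.3 percentage points lower from compound 1 to compound 3 (beyond the scatter) for naphthalen-1-yl in place of 3,4-dimethoxyphenyl on a sulfur, which is modest and downward. A similar modest fall is therefore expected in this assay from the high starting point. The expected step is a number 12.1 percentage points lower from compound 2 to compound 4 (beyond the scatter) on this estimate. For compound 4 the estimated value is 78% with an expected range of 55% to 93% in this test.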

Compound 4, percent growth inhibition at one concentration: 60.5%
Compound 4: the middle estimate sits 17.5 percentage points above what was measured; low and high end bracket the measured number.
By their numbers in this assay, from the lowest: compound 3; then compound 1; then compound 4; then compound 2.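

In this assay, tert-butyl in place of methoxy on an aromatic carbon, para to a large group, gives a number 29.6 percentage points lower from compound 2 to compound 4 (beyond the scatter), so the group at this position matters on the core of compound 2. The earlier step changed the whole group on sulfur on a different core, whereas this one isolates a single substituent. Nothing available bears on the reason for this fall.

Open, from the compounds shown here alone, is whether an amine, a carboxylic acid or a methyl group here would hold the level of compound 2. Also open, going by these compounds, is how a group at this place behaves on the core of compound 1.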